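Growth inhibition series: methoxy to bromo

A few compounds are considered here, and "the series" means these few. Any claim that something is new, unique, unknown or untested is made for them only; others in the source may bear on it.

Compound 1 `C=CCc1ccc(OCc2cn(-c3cc(OC)c(OC)c(OC)c3)nn2)c(O)c1`: 55.9%
Compound 2 `C=CCc1ccc(OCc2cn(-c3ccc(OC)cc3)nn2)c(O)c1`: 68.5%
Compound 3 `C=CCc1cc(O)c(O)c(CN2CCC(Cc3ccccc3)CC2)c1`: 83.4%

In a functional assay on SK-N-SH cells (Homo sapiens) for inhibition, read by MTT assay, with a stated time of 72 h, tested at 50 uM (a higher number here means more inhibition of growth at the concentration tested, a lower number less inhibition of growth), compound 2 stands second highest of the three, with 68.5%; its gaps to compound 1 and compound 3 both lie beyond the scatter. Compound 4 `C=CCc1ccc(OCc2cn(-c3ccc(Br)cc3)nn2)c(O)c1` differs from compound 2 in one place: bromo in place of methoxy on an aromatic carbon. This puts bromo in place of methoxy on an aromatic carbon, para to a large group. Going by the values given here, no measured pair shows this change or any other single change. No step beyond the scatter is expected in this assay, and no firm direction can be given. The expected change is a number 1.5 percentage points higher from compound 2 to compound 4 (within the scatter). Compound 4 is estimated at 70% (expected range 52% to 85%).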

Compound 4, percent growth inhibition at one concentration: 61.7%
Compound 4: middle estimate off by 8.3 percentage points, on the high side, and the stated range covers the measured number.
By their numbers in this assay, from the lowest: compounds 1, 4 and 2 (each within the scatter of the next, the first and the last beyond it); then compound 3.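

Bromo in place of methoxy, para to a large group, is the first single change that can be read in this series: in this assay it gives a number 6.8 percentage points lower from compound 2 to compound 4 (within the scatter) at the one concentration tested. At this position, 4-methoxyphenyl and 4-bromophenyl therefore cannot be told apart by this read-out. Nothing available bears on the reason for this result.

Going by these compounds, whether an amine, a carboxylic acid or a longer chain at the same position would give a step beyond the scatter stays open. Also open, on these data alone, is whether the same change would read alike at other concentrations.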